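The compounds below may be only part of what the source reports. "The series", "measured", "known", "first", "only" and "open" are said of these compounds alone.

In a functional assay on HCT-116 cells (Homo sapiens) for inhibition, read by CCK-8 assay, with a stated time of 72 h, tested at 8 uM (on this read-out lower numbers stand for less inhibition of growth and higher numbers for more inhibition of growth at the one concentration tested), compound 1 (`Nc1ccccc1NC(=O)/C=C/c1ccc(CSc2cccc(F)c2)cc1`) gives 3.22%, while compound 2 (`COc1ccc(SCc2ccc(C(=O)Nc3ccccc3N)cc2)cc1`) gives 90.1%, the higher of the two numbers by a gap well beyond the usual scatter. Compound 3 (`CCc1ccc(SCc2ccc(C(=O)Nc3ccccc3N)cc2)cc1`) has not yet been measured. It differs from compound 2 by having ethyl in place of methoxy on an aromatic carbon, para to a large group: ethyl in place of methoxy on an aromatic carbon. For the measured compounds named here, no measured pair shows this change, so in this assay no step beyond the scatter is expected, with the estimated step being a number 5.1 percentage points lower from compound 2 to compound 3 (within the scatter). For compound 3 the estimated value is 85%, with an expected range of 55% to 98%.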

Compound 3, percent growth inhibition at one concentration: 79.1%
Estimate against measurement, compound 3: 5.9 percentage points above, and the stated range covers the measured number.
By their numbers in this assay, from the lowest: compound 1; then compound 3; then compound 2.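

In this assay, ethyl in place of methoxy on this aromatic carbon, para to a large group, gives a modest step, a number 11 percentage points lower from compound 2 to compound 3 (beyond the scatter). So the position responds to this change, yet compound 3, which has no oxygen in that group, still holds a high 79.1%. Nothing measured here explains the step.

On these data alone, whether an amine, a carboxylic acid or a longer chain at this position would keep growth inhibition this high remains open.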